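This account rests on a few compounds, and the source may have more. Where it says the series, first, only, none or still open, it means among the compounds named here.

Three compounds sharing one core were examined in a functional assay on T47D cells (Homo sapiens) for cytotoxicity, read by colorimetric assay and MTT assay; a lower number here means a stronger inhibitor, a higher number a weaker inhibitor. Compound 1 `CCN(CC)C(=O)Cn1c(=O)c(-c2ccc(OC)cc2)cc2c(OC)cc(OC)cc21` gives 10000 nM. Compound 2 `COc1ccc(-c2cc3c(OC)cc(OC)cc3n(CC(=O)OCc3ccccc3)c2=O)cc1` gives 10000 nM, and compound 3 `COc1ccc(-c2cc3c(OC)cc(OC)cc3n(CCC(=O)OCc3ccccc3)c2=O)cc1` gives 10000 nM. The step of no change at the digits printed from compound 2 to compound 1 (within the scatter) accompanies the change (diethylamino in place of benzyloxy on a carbonyl carbon). The cores of compound 2 and compound 3 differ by (benzyloxycarbonyl)methyl in place of benzyloxycarbonyl on a saturated chain carbon bound to an aromatic nitrogen, with the step of no change at the digits printed from compound 2 to compound 3 (within the scatter); between compound 1 and compound 3 the step is no change at the digits printed from compound 1 to compound 3 (within the scatter).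

Compound 4 `CCN(CC)C(=O)CCn1c(=O)c(-c2ccc(OC)cc2)cc2c(OC)cc(OC)cc21` has not been measured. It differs from compound 3 by diethylamino in place of benzyloxy on a carbonyl carbon, the same change as that from compound 2 to compound 1, occurring twice among these compounds. Because no change at the digits printed from compound 2 to compound 1 (within the scatter) was flat, the step of no change at the digits printed from compound 3 to compound 4 (within the scatter) is expected to be flat as well. Compound 4 is therefore estimated at 10000 nM, between 5000 nM and 20000 nM.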

Compound 4, half-maximal inhibitory concentration: 10000 nM
Estimate against measurement, compound 4: no gap at the digits printed; the range from low to high includes it.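

In this assay, diethylamino in place of benzyloxy on a carbonyl carbon gives no change at the digits printed from compound 3 to compound 4 (within the scatter), and the comparisons with the shorter-chain compounds read no change at the digits printed from compound 2 to compound 4 (within the scatter) and no change at the digits printed from compound 1 to compound 4 (within the scatter). The change thus behaves alike on both cores: the same change on two cores in this assay, no change at the digits printed (within the scatter) from compound 2 to compound 1 and no change at the digits printed (within the scatter) from compound 3 to compound 4, 1.0-fold (0.00 log units) apart, within the scatter of two such steps This shows a flat step repeated, but it does not show that a step of real size would carry from one core to another, as all four compounds stand level.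

The compounds shown leave open whether a free carboxylic acid or a cyclic amine such as morpholine in place of these end groups would shift the value. They also leave open what a longer chain on the aromatic nitrogen would do.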